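Does piperazin-1-yl bring toxicity to compound 4?

The compounds below may be only part of what the source reports. "The series", "measured", "known", "first", "only" and "open" are said of these compounds alone.

In an ADME assay on NIH3T3 cells (Mus musculus) for cytotoxicity (a lower number here means that less compound is tolerated, a higher number that more compound is tolerated), compound 3 `CCOC(=O)CN(C)CC#Cc1cc2c(Nc3ccc(OCc4cccc(F)c4)c(Cl)c3)ncnc2s1` gives > 50 uM, which is a limit of the assay and not a number. Compound 2 `CC(C)(C)CC#Cc1cc2ncnc(Nc3ccc(OCc4cccc(F)c4)c(Cl)c3)c2s1` gives > 50 uM, also a limit. Compound 3 therefore stands at the limit of > 50 uM in this assay, at which 2 of the 3 values shown sit. Among the measured compounds shown here, the only exact number comes from compound 1 `CN1CCN(CC#Cc2cc3ncnc(Nc4ccc(OCc5cccc(F)c5)c(Cl)c4)c3s2)CC1`, which gives 4.8 uM.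

Compound 4 `Fc1cccc(COc2ccc(Nc3ncnc4sc(C#CCN5CCNCC5)cc34)cc2Cl)c1` changes one group of compound 3: piperazin-1-yl in place of ((ethoxycarbonyl)methyl)(methyl)amino on a saturated chain carbon bound to a triple-bonded carbon. This puts piperazin-1-yl in place of ((ethoxycarbonyl)methyl)(methyl)amino on a saturated chain carbon bound to a triple-bonded carbon.

For the measured compounds named here, one measured step bears on this change: an at least 10-fold higher number from compound 1 to compound 2 (1.01 log units; beyond the scatter). This large step replaces 4-methylpiperazin-1-yl with tert-butyl, and read backwards it links the ring-bearing group to the lower number. It is a single step, measured on the core of compound 1, which differs from the core shared by compound 3 and compound 4, so the range given here is kept wide.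

The expected change is large and points towards less compound tolerated, an estimated at least 6.2-fold lower number from compound 3 to compound 4 (0.79 log units; beyond the scatter). For compound 4 the estimate is 8 uM, with an expected range from 2.5 uM to 35 uM.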

Compound 4, half-maximal toxic concentration: 3.9 uM
Compound 4: the middle estimate sits 2.1-fold (0.31 log units) above what was measured, within the range that was stated.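

Compound 3 gives > 50 uM in this assay, and this value is a limit of the assay. Among the compounds shown here, on the core shared by compound 3 and compound 4, putting piperazin-1-yl in place of ((ethoxycarbonyl)methyl)(methyl)amino on a saturated chain carbon bound to a triple-bonded carbon gives an at least 12-fold lower number from compound 3 to compound 4 (1.10 log units; beyond the scatter), the first direct reading of this change at this position. Until now, the link between a piperazine-containing group and a lower number rested on a single step on the core of compound 1, an at least 10-fold higher number from compound 1 to compound 2 (1.01 log units; beyond the scatter), whereas the two steps now shown, on two different cores, point the same way and neither goes against that link.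

The compounds shown leave open whether the lower number follows the ring as a whole or the second ring nitrogen, a question that morpholin-4-yl, with an oxygen in place of that nitrogen, could help to settle. They also leave open whether a ring is needed at all, since an open-chain group such as 2-aminoethylamino at this place would carry a second nitrogen without one.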